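The compounds below may be only part of what the source reports. "The series", "measured", "known", "first", "only" and "open" are said of these compounds alone.

In a functional assay on OVCAR-3 cells (Homo sapiens) for antiproliferative activity, read by spectrophotometry, with a stated time of 2 days (on this read-out higher numbers stand for weaker inhibition of growth and lower numbers for stronger inhibition of growth), three compounds sharing one core have been measured so far. Compound 1 `COc1ccc(Nc2ncc(C(F)(F)F)c(N3Cc4cccc(N(C)S(C)(=O)=O)c4C3)n2)cc1C(F)(F)F` gives > 30000 nM, which is a limit of the assay and not a number. Compound 2 `Cc1ccc(Nc2ncc(C(F)(F)F)c(N3Cc4cccc(N(C)S(C)(=O)=O)c4C3)n2)cc1C` gives > 30000 nM, again a limit. Compound 3 `COc1cc(Nc2ncc(C(F)(F)F)c(N3Cc4cccc(N(C)S(C)(=O)=O)c4C3)n2)c(OC)cc1Cl` gives > 30000 nM, also a limit. Compound 3 therefore has no number of its own, and the set as a whole stands at the limit of > 30000 nM in this assay, at which 3 of the 3 values shown sit.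

Compound 4 `Cc1cc(F)ccc1Nc1ncc(C(F)(F)F)c(N2Cc3cccc(N(C)S(C)(=O)=O)c3C2)n1` keeps the shared core and carries 4-fluoro-2-methylphenyl in place of 4-chloro-2,5-dimethoxyphenyl on a nitrogen on an aromatic ring.

The measured steps that bear on this change swap the group at that same place. They are a step that the two limits leave unreadable from compound 1 to compound 3, a step that the two limits leave unreadable from compound 2 to compound 3 and a step that the two limits leave unreadable from compound 1 to compound 2. None of them has a readable size, so none offers a measured gain or loss to carry over, and none of the three groups tried so far has produced a number. The 4-fluoro-2-methylphenyl group itself has not been tested.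

The step expected in this assay is a number no higher from compound 3 to compound 4 (the limit leaves the size open), with nothing beyond the scatter foreseen in either direction. Compound 4 is estimated at 30000 nM, within an expected range of 10000 nM to 60000 nM, and the assay may well report only a limit again.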

Compound 4, concentration for 50% growth inhibition: > 30000 nM
Compound 4: only a limit was reported; the forecaster's own chance of this, stated with the estimate: 80%; the middle value sits exactly at the limit.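

Compound 4 gives > 30000 nM, which is a limit of the assay and not a number. Its steps from compound 1, compound 2 and compound 3 therefore cannot be read. The set now stands at a single point: the limit of > 30000 nM in this assay, at which 4 of the 4 values shown sit. The compounds shown leave open whether any group on this nitrogen would give a measurable value in this assay.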